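This account rests on a few compounds, and the source may have more. Where it says the series, first, only, none or still open, it means among the compounds named here.

Measured compounds in a functional assay on BXPC-3 cells (Homo sapiens) for antiproliferative activity, read by MTT assay, with a stated time of 24 h; on this read-out higher numbers stand for weaker inhibition and lower numbers for stronger inhibition:

compound 1 `CCn1c(C(=O)NCCN)ccc1C(CC)(CC)c1ccc(OCS(=O)(=O)c2ccccc2)c(C)c1` — 6430 nM
compound 2 `CCn1c(C(=O)N[C@H](CO)C(C)C)ccc1C(CC)(CC)c1ccc(OCS(=O)(=O)c2ccccc2)c(C)c1` — 7720 nM
compound 3 `CCn1c(C(=O)NC2(C(=O)O)CC2)ccc1C(CC)(CC)c1ccc(OCS(=O)(=O)c2ccccc2)c(C)c1` — reported only as a limit of the assay: > 50000 nM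

Compound 2 holds the highest of the two real numbers in this assay; its nearest neighbour is compound 1, with a 1.2-fold higher number from compound 1 to compound 2 (0.08 log units; within the scatter), so the two are not separated. Compound 3 sits at the assay limit of > 50000 nM in this assay, at which 1 of the 3 values shown sits, and gives no number.

Compound 4 `CCn1c(C(=O)N[C@@H](CC(=O)O)C(=O)O)ccc1C(CC)(CC)c1ccc(OCS(=O)(=O)c2ccccc2)c(C)c1` differs from compound 2 in one place: 1,2-dicarboxyethyl in place of 1-(hydroxymethyl)-2-methylpropyl on an amide-type nitrogen. The change on the amide-type nitrogen, from 1-(hydroxymethyl)-2-methylpropyl to 1,2-dicarboxyethyl, brings in carboxyl groups where the shown series has only one precedent, compound 3 with 1-carboxycyclopropyl. On these data alone, that precedent reads an at least 6.4-fold higher number from compound 2 to compound 3 (0.81 log units; beyond the scatter) and an at least 7.7-fold higher number from compound 1 to compound 3 (0.89 log units; beyond the scatter), both running into the limit (the limit of > 50000 nM in this assay, at which 1 of the 3 values shown sits), so their true size is unknown and at least modest.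

On that basis compound 4 is expected to lose activity in this assay relative to compound 2, with an estimated step of a 7.8-fold higher number from compound 2 to compound 4 (0.89 log units; beyond the scatter). The estimate for compound 4 is 60000 nM, with a range from 15000 nM to 200000 nM; it is judged more likely than not that the assay returns only a limit for compound 4, as it did for compound 3 at the limit of > 50000 nM in this assay, at which 1 of the 3 values shown sits.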

Compound 4, half-maximal inhibitory concentration: > 50000 nM
Compound 4: a limit, no number (the forecaster's own chance of this, stated with the estimate: 65%); the middle value does not contradict the limit.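

In this assay compound 4 gives only a limit, > 50000 nM, so the loss on the amide-type nitrogen is no longer tied to the single case of 1-carboxycyclopropyl. The steps of an at least 6.4-fold higher number from compound 2 to compound 4 (0.81 log units; beyond the scatter) and an at least 7.7-fold higher number from compound 1 to compound 4 (0.89 log units; beyond the scatter) are both bounded by that limit, and they show that 1,2-dicarboxyethyl, which has no ring, falls on the same side as the ring-bearing 1-carboxycyclopropyl, while compound 1 and compound 2, with no carboxyl group, keep real numbers. Compound 3 and compound 4 are both limits, so the step between them cannot be read and any difference between one carboxyl group and two stays hidden, with the two carboxyl-bearing groups accounting for every value at: the limit of > 50000 nM in this assay, at which 2 of the 4 values shown sit.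

Still open, on these data alone, is whether the carboxyl group itself goes with the loss, a question that a methyl ester or a primary amide in its place on the 1,2-dicarboxyethyl chain would address. Also open, as far as these compounds go, is how far the real numbers extend among groups without a carboxyl, for instance a longer aminoalkyl chain or a tertiary amine in place of 2-aminoethyl.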